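This account rests on a few compounds, and the source may have more. Where it says the series, first, only, none or still open, it means among the compounds named here.

Measured compounds:
- compound 1, `Cc1ccncc1-c1cc(F)cc(-n2nnc(-c3ncc[nH]3)n2)c1`: 3.5 nM
- compound 2, `Cc1c[nH]c(-c2nnn(-c3cc(F)cc(C#N)c3)n2)n1`: 19 nM

In an assay for binding affinity to metabotropic glutamate receptor 5 (Rattus norvegicus) (on this read-out lower numbers stand for stronger inhibition and higher numbers for weaker inhibition), compound 2 gives 19 nM, the higher of the two numbers in hand. Among the measured compounds shown here, compound 1 gives 3.5 nM, a gap that lies beyond the usual scatter; the two compounds differ in more than one place, so no single step between them is defined, and only the two values themselves are known.

Compound 3, `N#Cc1cc(F)cc(-n2nnc(-c3ncc[nH]3)n2)c1`, is not yet measured. It arises from compound 2 by hydrogen in place of methyl on an aromatic carbon, which is hydrogen in place of methyl on an aromatic carbon. For the measured compounds named here, no measured pair shows the effect of this change on the shared core, so it is expected to stay within the scatter in this assay, with no clear direction; the step from compound 2 to compound 3 is estimated as a 1.1-fold higher number from compound 2 to compound 3 (0.02 log units; within the scatter). In this assay compound 3 is therefore expected at about 20 nM, within a range of 7 nM to 60 nM.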

Compound 3, inhibition constant: 9.3 nM
For compound 3 the middle estimate is 2.2-fold (0.33 log units) above the measured one; measured number inside the range.
By their numbers in this assay, from the lowest: compound 1; then compound 3; then compound 2.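

In this assay, among the compounds shown here, the change from 4-methyl-1H-imidazol-2-yl to 1H-imidazol-2-yl gives a 2.0-fold lower number from compound 2 to compound 3 (0.31 log units; beyond the scatter), the first direct reading at this position: the methyl is not required for binding, and with the nitrile retained, its loss gives a modest improvement. With the 1H-imidazol-2-yl held constant, cyano in place of 4-methylpyridin-3-yl gives a 2.7-fold higher number from compound 1 to compound 3 (0.42 log units; beyond the scatter), a modest step that favours the 4-methylpyridin-3-yl, so both groups are accommodated on that aromatic carbon. No supporting data explain either step.

For the compounds shown here, it remains open whether removing the methyl gives the same step when 4-methylpyridin-3-yl replaces the nitrile, as only one matched pair covers this change. From the compounds shown here alone, how an ethyl group, a chlorine atom or an amine would read on the same aromatic carbon of the five-membered ring also remains open.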